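A Smaller Aryl Group on the Shared Core

A few compounds are considered here, and "the series" means these few. Any claim that something is new, unique, unknown or untested is made for them only; others in the source may bear on it.

Compound 1 `Cc1cc(=O)n(-c2ccccc2C(F)(F)F)nc1C(=O)Nc1ccc(Oc2ncnc3sccc23)c(F)c1` and compound 2 `Cc1cc(=O)n(-c2ccccc2OC(F)(F)F)nc1C(=O)Nc1ccc(Oc2ncnc3sccc23)c(F)c1` share one core and differ in a single aromatic substituent. In a functional assay on MCF7 cells (Homo sapiens) for cytotoxicity, read by MTT assay, with a stated time of 72 h (on this read-out higher numbers stand for weaker inhibition and lower numbers for stronger inhibition), compound 1 gives 13800 nM. For compound 2 this assay reports only a limit, > 40000 nM. The one measured step, an at least 2.8-fold higher number from compound 1 to compound 2 (0.46 log units; beyond the scatter), is bounded by the limit of > 40000 nM in this assay, at which 1 of the 2 values shown sits, so compound 2 stands at the weaker end of the two numbers shown. Compound 3 `Cc1cc(=O)n(-c2ccc(F)cc2)nc1C(=O)Nc1ccc(Oc2ncnc3sccc23)c(F)c1` carries 4-fluorophenyl in place of 2-(trifluoromethoxy)phenyl on an aromatic nitrogen. Within the data shown here, only the step from compound 1 to compound 2 bears on this change, and it shows that altering the substituent on this phenyl ring shifted the number beyond the scatter; whether a 4-fluorophenyl brings the number back toward that of compound 1 cannot be read from these two values. The step expected here is an at least 2.6-fold lower number from compound 2 to compound 3 (0.42 log units; beyond the scatter). Compound 3 is estimated at 15000 nM, within 4000 nM to 60000 nM.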

Compound 3, half-maximal inhibitory concentration: 12300 nM
Compound 3: middle estimate off by 1.2-fold (0.09 log units), on the high side; low and high end bracket the measured number.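

In this assay, 4-fluorophenyl in place of 2-(trifluoromethoxy)phenyl on the aromatic nitrogen gives an at least 3.2-fold lower number from compound 2 to compound 3 (0.51 log units; beyond the scatter). The value of compound 2 is a limit, so this step has a bound and no exact size: the limit of > 40000 nM in this assay, at which 1 of the 3 values shown sits. Set against 2-(trifluoromethyl)phenyl, the same change gives a 1.1-fold lower number from compound 1 to compound 3 (0.05 log units; within the scatter), which shows what the earlier pair could not: an aryl group with a single fluorine and no ortho group reads the same as the aryl group of compound 1 at this place.

What the compounds shown leave open is how an unsubstituted phenyl or a 2-fluorophenyl would read here. Also open, on these data alone, is whether an amine or a carboxylic acid on this phenyl ring would move the number at all.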